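Chloro added between two ring nitrogens of a purine-like core

The source may hold more compounds than are shown below. What is called first, only, known or untested is meant among the compounds shown, and "the series" means these compounds.

Measured compounds:
compound 1 `ClCc1ccccc1Cn1cnc2c(Cl)nc(Cl)nc21`: 810 nM
compound 2 `ClCc1cccc(Cn2cnc3ncnc(Cl)c32)c1`: 1580 nM
compound 3 `ClCc1cccc(Cn2cnc3c(Cl)ncnc32)c1`: 7760 nM

In a functional assay on MCF7 cells (Homo sapiens) for cytotoxicity, read by sulforhodamine B assay, with a stated time of 48 h (on this read-out higher numbers stand for weaker inhibition of growth and lower numbers for stronger inhibition of growth), compound 2 gives 1580 nM. Among the three measured numbers it is the second highest. Its nearest neighbour is compound 1, which gives 810 nM, and the gap between the two lies within the scatter of this assay, so the two cannot be told apart. Compound 3 gives 7760 nM, a number well beyond the scatter above compound 2, so compound 2 shows stronger inhibition of growth than compound 3.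

Compound 4 `ClCc1cccc(Cn2cnc3nc(Cl)nc(Cl)c32)c1` has not yet been measured. It differs from compound 2 by chloro in place of hydrogen on an aromatic carbon. Going by the values given here, no single-change step between measured compounds is available to calibrate this change. Compound 1 carries the same two chloro groups on its core as compound 4, with a differently placed chloromethyl group, and its value sits close to that of compound 2. Compound 4 is therefore expected to show a step from compound 2 of a 1.6-fold lower number from compound 2 to compound 4 (0.20 log units; within the scatter), toward slightly stronger inhibition of growth, within or only just beyond the scatter. Compound 4 is estimated at 1000 nM, with a range from 400 nM to 2500 nM.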

Compound 4, concentration for 50% growth inhibition: 1510 nM
Estimate against measurement, compound 4: 1.5-fold (0.18 log units) below; measured number inside the range.
By their numbers in this assay, from the lowest: compounds 1, 4 and 2 (each within the scatter of the next); then compound 3.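

In this assay the step for chloro in place of hydrogen on this aromatic carbon, between two ring nitrogen atoms, is a 1.0-fold lower number from compound 2 to compound 4 (0.02 log units; within the scatter) and so compound 2 and compound 4 cannot be told apart. Going by these compounds alone, this is the only single-change step, and the earlier compounds offered no direct reading of this position. It shows that, with the chloromethyl group placed as in compound 2, this change produces no difference that the assay can resolve, and the data offered give no explanation for that.

On these data alone, whether an amine, a methoxy group or a longer chain at this position would behave like chloro remains open. As far as these compounds go, it is also open whether chloro would give the same result with the chloromethyl group placed differently.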